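Swapping a Six-Membered Ring for a Five-Membered One

The compounds below may be only part of what the source reports. "The series", "measured", "known", "first", "only" and "open" are said of these compounds alone.

Of the compounds shown here, three have been tested in an assay on HEK293 cells for agonist activity at transient receptor potential cation channel subfamily M member 8 (Homo sapiens), read by fluorescence and calcium flux, with a stated time of 15 min; on this read-out lower numbers stand for an effect already at smaller amounts and higher numbers for an effect only at larger amounts of compound. Compound 1 `CCN(Cc1cccs1)C(=O)c1cc2cc(C)ccc2o1` gives 120 nM. Compound 3 `O=C(COc1ccc2c(c1)CCC2)N(Cc1cccs1)c1ccn[nH]1` gives 0.001 nM. Compound 2 `Cc1ccc(OCC(=O)N(Cc2cccs2)c2ncccn2)cc1` gives 3700 nM, the highest of the three numbers, and its distance from each of the others lies beyond the scatter. The new compound 4 `Cc1ccc(OCC(=O)N(Cc2cccs2)c2ccon2)cc1` keeps everything else of compound 2 and changes only the group on the amide-type nitrogen: 1,2-oxazol-3-yl in place of pyrimidin-2-yl on an amide-type nitrogen. Among the measured compounds shown here, no two measured compounds differ in a single place, so no direct pair shows what such a swap does. Still, a lower number is expected for compound 4, because compound 3 gives 0.001 nM while also carrying a five-membered aromatic ring with 2 hetero atoms on its amide-type nitrogen, though compound 3 differs in other places too. The step of a 3.1-fold lower number from compound 2 to compound 4 (0.49 log units; beyond the scatter) is expected to be modest. Compound 4 is estimated at 1200 nM, within 150 nM to 8000 nM.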

Compound 4, half-maximal effective concentration: 2 nM
Compound 4: middle estimate off by 600-fold (2.78 log units), on the high side; measured number below the stated range.
By their numbers in this assay, from the lowest: compound 3; then compound 4; then compound 1; then compound 2.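

In this assay, the group on the amide-type nitrogen turns out to matter greatly: 1,2-oxazol-3-yl in place of pyrimidin-2-yl brings a 1900-fold lower number from compound 2 to compound 4 (3.27 log units; beyond the scatter) through this one change alone. The two groups have the same counts of hetero atoms, hydrogen-bond donors and acceptors, so those counts do not separate them, although their ring sizes differ. Nothing measured here explains the gap.

On these data alone, whether another five-membered ring, such as thiazol-2-yl, would give a similarly low number remains open. So does the effect of a plain methyl group at this position.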